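The source may hold more compounds than are shown below. What is called first, only, known or untested is meant among the compounds shown, and "the series" means these compounds.

Compound 1 `O=C1O[C@@H](CN2CCCCC2)CN1c1ccc(-n2cc(-c3ccccn3)cn2)c(F)c1`: in an ADME assay on L02 cells (Homo sapiens) for cytotoxicity, read by MTT assay, with a stated time of 48 h (a lower number here means a stronger inhibitor, a higher number a weaker inhibitor), compound 1 gives > 400 ug/mL, which is a limit of the assay.
Compound 2 `O=C1O[C@@H](CSc2cccs2)CN1c1ccc(-n2cc(-c3ccccn3)cn2)c(F)c1`: in this assay compound 2 gives > 400 ug/mL, also a limit.
Compound 3 `O=C(NC[C@H]1CN(c2ccc(-n3cc(-c4ccccn4)cn3)c(F)c2)C(=O)O1)C(F)F`: in this assay compound 3 gives > 400 ug/mL, again a limit.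

Compound 1 therefore stands only at a limit in this assay, and the other two values are limits as well: the limit of > 400 ug/mL in this assay, at which 3 of the 3 values shown sit. Compound 4 `O=C1O[C@@H](CNC(=O)C(F)(F)F)CN1c1ccc(-n2cc(-c3ccccn3)cn2)c(F)c1` differs from compound 1 in one place: ((trifluoromethyl)carbonyl)amino in place of piperidin-1-yl on a saturated chain carbon bound to a saturated ring carbon. The measured steps at the same place are a step that the two limits leave unreadable from compound 1 to compound 2 and a step that the two limits leave unreadable from compound 1 to compound 3, and both are unreadable due to the limit of > 400 ug/mL in this assay, at which 3 of the 3 values shown sit. No step beyond the scatter can be read from them, so the expected step is a number no higher from compound 1 to compound 4 (the limit leaves the size open). Compound 4 is expected to give 400 ug/mL, within 200 ug/mL to 800 ug/mL, most likely reported as a limit once more.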

Compound 4, half-maximal inhibitory concentration: > 400 ug/mL
Compound 4 gave a limit, no number (the forecaster's own chance of this, stated with the estimate: 85%); the middle value sits exactly at the limit.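

The steps from compound 1, compound 2 and compound 3 to compound 4 cannot be read, because all four compounds stand at a limit rather than a number: the limit of > 400 ug/mL in this assay, at which 4 of the 4 values shown sit. Left open is whether any of these groups changes the result in this assay at all, and by how much.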